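Swapping the Ring Amine on a Flavone Scaffold

The source may report more compounds than this note shows. Statements on the series, on what has been measured and on what is new or still open speak of the compounds shown alone.

Measured so far:
- Compound 1 `COc1c(O)cc(O)c2c(=O)cc(-c3ccc(N4CCCNCC4)cc3)oc12`: 31600 nM
- Compound 2 `Cc1n[nH]c(C)c1Oc1c(O)cc(O)c2c(=O)cc(-c3ccc(N4CCN(c5ccccc5)CC4)cc3)oc12`: 3500 nM
- Compound 3 `O=c1cc(-c2ccc(N3CCCNCC3)cc2)oc2c(OC3CCCCC3)c(O)cc(O)c12`: 16200 nM

In an assay on cells for inhibition of ubiquitin carboxyl-terminal hydrolase 8 (Homo sapiens), read by fluorescence, with a stated time of 30 min (on this read-out lower numbers stand for stronger inhibition and higher numbers for weaker inhibition), compound 1 gives the highest number of the three. Its nearest neighbour is compound 3, reached by a 2.0-fold lower number from compound 1 to compound 3 (0.29 log units; within the scatter). Compound 2 differs from compound 1 in two places, so its value stands alone as a comparison.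

Compound 4 `COc1c(O)cc(O)c2c(=O)cc(-c3ccc(N4CCN(C)CC4)cc3)oc12` is not yet measured. It differs from compound 1 by 4-methylpiperazin-1-yl in place of 1,4-diazepan-1-yl on an aromatic carbon. Among the compounds with values here, no measured step changes this ring amine on its own, and the single known step, the one from compound 1 to compound 3, concerns a different part of the molecule. With nothing to draw on, the expected step of a 1.3-fold lower number from compound 1 to compound 4 (0.10 log units; within the scatter) is none beyond the scatter. Compound 4 is therefore estimated at 25000 nM, in the range 8000 nM to 80000 nM.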

Compound 4, half-maximal inhibitory concentration: 16500 nM
The estimate for compound 4 lay 1.5-fold (0.18 log units) above the measured number, and the stated range covers the measured number.
By their numbers in this assay, from the lowest: compound 2; then compounds 3, 4 and 1 (each within the scatter of the next).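

In this assay exchanging 1,4-diazepan-1-yl for 4-methylpiperazin-1-yl on the aromatic carbon gives a 1.9-fold lower number from compound 1 to compound 4 (0.28 log units; within the scatter). Within the data shown here, this is the first single change read at this position, and it shows that going from a seven-membered to a six-membered ring, and from 1 hydrogen-bond donor to 0, leaves the number within the scatter. No measurement shown here explains this result.

Still open, going by these compounds, is whether a different group in this place, such as an open-chain dimethylamino group or a morpholine ring, would move the number beyond the scatter.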